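Ortho-Chlorobenzamide in Place of the Aryl Urea

The source may report more compounds than this note shows. Statements on the series, on what has been measured and on what is new or still open speak of the compounds shown alone.

Compound 1 `C[C@H](NC(=O)[C@H](C)[C@H]1CC[C@@H](c2ccnc3ccc(F)cc32)CC1)c1ccc(Cl)cc1`: > 1000 nM
Compound 2 `C[C@@H](CNc1ccc(Cl)cc1)[C@H]1CC[C@@H](c2ccnc3ccc(F)cc32)CC1`: 44 nM
Compound 3 `C[C@@H](NC(=O)Nc1ccc(Cl)cc1)[C@H]1CC[C@@H](c2ccnc3ccc(F)cc32)CC1`: 280 nM

Of the compounds shown here, three on a shared core have been read in an assay on blood for inhibition of Indoleamine 2,3-dioxygenase 1 (Homo sapiens), read by mass spectrometry, with stated times of 4 h and 18 h; a higher number here means a weaker inhibitor, a lower number a stronger inhibitor. Compound 1, the reversed amide, returns only a limit, > 1000 nM, which is the assay's reporting edge (the limit of > 1000 nM in this assay, at which 1 of the 3 values shown sits) and not a number. Compound 2, the amine, gives 44 nM. Compound 3, the aryl urea, gives 280 nM, the higher of the two numbers; its gap to compound 2 lies beyond the usual scatter of repeated measurements.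

The next step leads from compound 3 to compound 4 `C[C@@H](NC(=O)c1ccccc1Cl)[C@H]1CC[C@@H](c2ccnc3ccc(F)cc32)CC1`. The change is 2-chlorophenyl in place of (4-chlorophenyl)amino on a carbonyl carbon, so that the (4-chlorophenyl)carbamoyl of compound 3 becomes a (2-chlorophenyl)carbonyl, and one hydrogen-bond donor is lost.

Among the measured compounds shown here, no measured pair in this set carries exactly this change, so the size of the step is open. On the numbers shown, with compound 1 at its limit and compound 3 already the higher of the two numbers, the author expects the step from compound 3 to compound 4 to be a 1.4-fold higher number from compound 3 to compound 4 (0.15 log units; within the scatter), a modest move toward a higher number. Compound 4 is therefore estimated at 400 nM, within a range from 100 nM to 2000 nM, in this assay.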

Compound 4, half-maximal inhibitory concentration: 135 nM
Compound 4: the middle estimate sits 3.0-fold (0.47 log units) above what was measured, within the range that was stated.
By their numbers in this assay, from the lowest: compound 2; then compound 4; then compound 3. At a limit, above all of these: compound 1.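

In this assay the swap of (4-chlorophenyl)amino for 2-chlorophenyl on the carbonyl carbon gives a 2.1-fold lower number from compound 3 to compound 4 (0.32 log units; beyond the scatter) and shows that this position does not depend on the hydrogen-bond donor of the urea: the (2-chlorophenyl)carbonyl of compound 4 reads better than the (4-chlorophenyl)carbamoyl of compound 3, though the step is modest. Among the compounds shown here, until now, no step in this set had been read at all, so this is the first direct measure of what a change at this carbonyl carbon does. For the compounds shown here, two things change together here, the loss of the amide-type nitrogen carrying the aryl group and the different placing of the chlorine named in the two groups, and the single step does not divide between them.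

A 4-chlorophenyl or a (2-chlorophenyl)amino on the same carbonyl carbon would part those two changes, and a plain phenyl would show what the chlorine itself contributes, but the compounds shown include none of these. Nothing measured here bears on why the number moved.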